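Moving from fluorine to a carboxylic acid on the amide

A few compounds are considered here, and "the series" means these few. Any claim that something is new, unique, unknown or untested is made for them only; others in the source may bear on it.

Of the compounds shown here, three sharing one core have been tested in a functional assay on the whole organism for inhibition, with Rattus norvegicus as the target, read by paw edema, with stated times of 30 min and 5 h, at a dose of 0.28 mmol/kg by the oral route; a lower number here means less inhibition, a higher number more inhibition at the dose given (going by the name of the read-out). Compound 1, `COc1ccc(-n2nc(C(N)=O)nc2-c2cc(OC)c(OC)c(OC)c2)cc1`, gives 64%. Compound 2, `COc1ccc(NC(=O)c2nc(-c3cc(OC)c(OC)c(OC)c3)n(-c3ccc(OC)cc3)n2)cc1`, gives 51%. Compound 3, `COc1ccc(-n2nc(C(=O)Nc3cccc(F)c3)nc2-c2cc(OC)c(OC)c(OC)c2)cc1`, gives 53%, which stands second highest of the three: its number sits within the scatter of compound 2 and is beyond the scatter below compound 1.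

The next compound, compound 4, `COc1ccc(-n2nc(C(=O)Nc3ccc(C(=O)O)cc3)nc2-c2cc(OC)c(OC)c(OC)c2)cc1`, differs from compound 3 in one place: 4-carboxyphenyl in place of 3-fluorophenyl on an amide-type nitrogen. The steps measured so far bear on this only in part. Putting an aromatic group onto the amide-type nitrogen cost something, as a number 13 percentage points lower from compound 1 to compound 2 (beyond the scatter) and a number 11 percentage points lower from compound 1 to compound 3 (beyond the scatter) show, while exchanging one such aromatic group for another, a number 2 percentage points higher from compound 2 to compound 3 (within the scatter), stayed within the scatter. Among the compounds with values here, no measured step involves a carboxy group, so its effect is unknown. The swap from 3-fluorophenyl to 4-carboxyphenyl is therefore expected to give a step of about a number 3 percentage points lower from compound 3 to compound 4 (within the scatter) in this assay, not clearly beyond the scatter. Compound 4 is estimated at 50%, within a range of 37% to 63%.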

Compound 4, a percentage reported as inhibition, in the whole organism at one dose (the size of the read-out at that dose, not a potency): 60%
Compound 4: the middle estimate sits 10 percentage points below what was measured, within the range that was stated.
By their numbers in this assay, from the lowest: compounds 2, 3, 4 and 1 (each within the scatter of the next, the first and the last beyond it).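

In this assay, the step of a number 4 percentage points lower from compound 1 to compound 4 (within the scatter) shows that an aromatic group on the amide-type nitrogen need not move the number beyond the scatter, unlike the steps of a number 13 percentage points lower from compound 1 to compound 2 (beyond the scatter) and a number 11 percentage points lower from compound 1 to compound 3 (beyond the scatter) for the other two aromatic groups. Even so, the three aromatic groups cannot be told apart in this assay: 4-carboxyphenyl in place of 3-fluorophenyl gives a number 7 percentage points higher from compound 3 to compound 4 (within the scatter) and carboxy in place of methoxy gives a number 9 percentage points higher from compound 2 to compound 4 (within the scatter) as its step. Nothing measured here explains these numbers.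

Going by these compounds, what a small alkyl chain such as ethyl on the amide-type nitrogen would give remains open. So does the effect of an amine or a tetrazole in place of the carboxy group on the aromatic ring.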